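The source may hold more compounds than are shown below. What is called first, only, known or untested is meant among the compounds shown, and "the series" means these compounds.

Compound 1 `O=C(Nc1ccccc1)N1c2ccnn2CC1c1ccccc1` limit > 1000 nM
Compound 2 `O=C(Nc1cccc(F)c1)N1c2ccnn2CC1c1ccccc1` limit > 1000 nM
Compound 3 `CCOC(=O)c1cnn2c1N(C(=O)Nc1ccccc1)C(c1ccccc1)C2` limit > 1000 nM

In a functional assay on cells (Neutrophil, Homo sapiens) for inhibition, with a stated time of 10 min (on this read-out higher numbers stand for weaker inhibition and lower numbers for stronger inhibition), compound 3 stands at > 1000 nM, which is a limit and not a number. Among the compounds with values here, the entries for compound 1 and compound 2 are limits too, so no compound yet has a measured potency.

Compound 4 `CCOC(=O)c1cnn2c1N(C(=O)Nc1cccc3ccccc13)C(c1ccccc1)C2` keeps the ethoxycarbonyl of compound 3 and carries naphthalen-1-yl in place of phenyl on an amide-type nitrogen. The counted difference is naphthalen-1-yl in place of phenyl on an amide-type nitrogen.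

Within the data shown here, two measured steps bear on this only loosely, since neither makes the same exchange. Fluoro in place of hydrogen on an aromatic carbon gives a step that the two limits leave unreadable from compound 1 to compound 2, and ethoxycarbonyl in place of hydrogen on an aromatic carbon gives a step that the two limits leave unreadable from compound 1 to compound 3. Neither has a readable size, so they offer no size or direction to carry over.

The expectation is therefore that compound 4 stays close to the others, and a further limit is the likeliest report in this assay because the limit of > 1000 nM in this assay, at which 3 of the 3 values shown sit, is all that has been seen so far. The expected change is a step that the limit leaves unreadable from compound 3 to compound 4, with no firm direction. For compound 4 the estimated value is 1500 nM, within an expected range of 150 nM to 10000 nM.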

Compound 4, half-maximal inhibitory concentration: 206 nM
The estimate for compound 4 lay 7.3-fold (0.86 log units) above the measured number; low and high end bracket the measured number.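

In this assay, within the data shown here, naphthalen-1-yl in place of phenyl on an amide-type nitrogen gives an at least 4.8-fold lower number from compound 3 to compound 4 (0.68 log units; beyond the scatter), so the swap moves the series towards stronger inhibition, and this is the first step with a readable size and direction. The earlier steps shown here, on aromatic carbons of the shared core, cannot be read, which makes this amide-type nitrogen, whose other neighbour is the carbonyl carbon, the first place where a change is seen to alter the read-out; the exchange adds a second six-membered aromatic ring of carbon only, while the counts of hydrogen-bond donors and acceptors and the net charge stay the same. Compound 4 is the only compound shown that has left the limit, and the others remain there: the limit of > 1000 nM in this assay, at which 3 of the 4 values shown sit.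

Among the compounds shown, naphthalen-1-yl occurs only together with the ethoxycarbonyl, so it stays open whether the step would also appear with hydrogen in that place, as in compound 1. Also open, on these data alone, is what a carboxylic acid in place of the ethoxycarbonyl, or a chloro or methoxy group on the naphthalen-1-yl, would do to the inhibition.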